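A few compounds are considered here, and "the series" means these few. Any claim that something is new, unique, unknown or untested is made for them only; others in the source may bear on it.

Compound 2 `Nc1nc(O)c2c(n1)n(C1OC(CO)[C@@H](O)[C@H]1O)c(=O)n2Cc1ccc(Cl)cc1` is the weaker of the two compounds measured in a functional assay on the whole organism (B cells) with Mus musculus as the target; a lower number here means a smaller maximal response, a higher number a larger maximal response: compound 2 gives 15%, while compound 1 `Nc1nc(O)c2c(n1)n(C1OC(CO)[C@@H](O)[C@H]1O)c(=O)n2C/C=C/c1ccccc1` gives 73%. Among the compounds with values here, the only measured step, a number 58 percentage points lower from compound 1 to compound 2 (beyond the scatter), came with 4-chlorophenyl in place of 2-phenylethenyl on a saturated chain carbon bound to an aromatic nitrogen. Compound 3 `CCn1c(=O)n(C2OC(CO)[C@@H](O)[C@H]2O)c2nc(N)nc(O)c21` differs from compound 2 at the same position: methyl in place of 4-chlorophenyl on a saturated chain carbon bound to an aromatic nitrogen. The measured step bears on this only in that it shows the group on this carbon matters a great deal in this assay; it says nothing about a methyl there, so the direction is open. Given that compound 2 already stands at 15%, the expected step of a number 15 percentage points higher from compound 2 to compound 3 (beyond the scatter) is small to moderate and uncertain in sign. Compound 3 is therefore estimated at 30%, within 5% to 65%.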

Compound 3, largest response reached (reported as maximal response), in percent of the reference or control that the assay uses: 82%
Compound 3: the middle estimate sits 52 percentage points below what was measured, and the stated range ends below it.
By their numbers in this assay, from the lowest: compound 2; then compounds 1 and 3 (each within the scatter of the next).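

In this assay, a small group on this carbon carries a large maximal response, and the low number of compound 2 does not belong to the position as such: a number 67 percentage points higher from compound 2 to compound 3 (beyond the scatter), with methyl in place of 4-chlorophenyl. With a number 9 percentage points higher from compound 1 to compound 3 (within the scatter), methyl and 2-phenylethenyl cannot be told apart, so an aromatic ring on this chain does not by itself set the number: compound 1 carries one and stays within the scatter of compound 3, while compound 2 carries one and lies far beyond it. No measurement on hand accounts for the drop seen with 4-chlorophenyl.

As far as these compounds go, whether the chlorine or the benzyl group itself goes with the low number remains open, and an unsubstituted benzyl group would separate the two. From the compounds shown here alone, how a longer chain such as butyl, or a chain ending in an amine or a carboxylic acid, behaves at this place is also open.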